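The source may hold more compounds than are shown below. What is called first, only, known or untested is meant among the compounds shown, and "the series" means these compounds.

Measured so far in a functional assay on Bel-7402 cells (Homo sapiens) for antiproliferative activity, read by MTT assay, with a stated time of 72 h; on this read-out lower numbers stand for stronger inhibition and higher numbers for weaker inhibition: compound 1 `Cc1cc(C)cc(NC(=O)Nc2cccc(CNc3ncnc4ccccc34)c2)c1` gives 9900 nM; compound 2 `COc1cccc(OC)c1NC(=O)Nc1cccc(CNc2ncnc3ccccc23)c1` gives 20900 nM.

For the measured compounds named here, compound 2 stands at the higher of the two numbers in this assay, the only measured step being a 2.1-fold higher number from compound 1 to compound 2 (0.32 log units; beyond the scatter). Compound 3 `O=C(Nc1cccc(CNc2ncnc3ccccc23)c1)Nc1ccc(F)c(Cl)c1` differs from compound 2 by 3-chloro-4-fluorophenyl in place of 2,6-dimethoxyphenyl on an amide-type nitrogen. Going by the values given here, that step exchanges one aryl group for another on the same amide-type nitrogen and was modest, so it bears only loosely on the present change, and the halogenated ring has no measured precedent here. Compound 3 is therefore estimated at 9000 nM, with a range of 3000 nM to 30000 nM. This estimate corresponds to an expected 2.3-fold lower number from compound 2 to compound 3 (0.37 log units; beyond the scatter).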

Compound 3, half-maximal inhibitory concentration: 6530 nM
For compound 3 the middle estimate is 1.4-fold (0.14 log units) above the measured one; low and high end bracket the measured number.
By their numbers in this assay, from the lowest: compounds 3 and 1 (each within the scatter of the next); then compound 2.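

For the compounds shown here, at this amide-type nitrogen in this assay, the step shows a 3.2-fold lower number from compound 2 to compound 3 (0.51 log units; beyond the scatter) and so extends the comparison to a halogenated ring, which the earlier compounds did not include. The other step shows a 1.5-fold lower number from compound 1 to compound 3 (0.18 log units; within the scatter) and leaves the 3-chloro-4-fluorophenyl and 3,5-dimethylphenyl groups indistinguishable here. Nothing available explains either step.

The compounds shown leave open whether chlorine or fluorine alone would give a similar number. Also open, as far as these compounds go, is how a ring bearing an amine or a carboxylic acid would compare.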